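The compounds below may be only part of what the source reports. "The series", "measured", "known", "first", "only" and "open" are said of these compounds alone.

The measured compounds:
compound 1, `O=S(=O)(NCCCNCc1ccc(Cl)cc1)c1cc(C(F)(F)F)cc(C(F)(F)F)c1`, 2700 nM
compound 2, `O=S(=O)(NCCNCc1ccc(-c2ccccc2)cc1)c1cc(C(F)(F)F)cc(C(F)(F)F)c1`, 2400 nM
compound 3, `COc1cccc(CNCCCNS(=O)(=O)c2cc(C(F)(F)F)cc(C(F)(F)F)c2)c1`, 6400 nM

All three were tested in a functional assay on Capan-2 cells (Homo sapiens) for inhibition, read by MTT assay, with a stated time of 72 h; a lower number here means a stronger inhibitor of growth, a higher number a weaker inhibitor of growth. Among these three numbers compound 1 stands second highest: compound 2 lies nearest to it, within the scatter, while compound 3 lies furthest, with a modest step: a 2.4-fold higher number from compound 1 to compound 3 (0.37 log units; beyond the scatter). That step swaps one aryl group for another on the saturated chain carbon bound to an amine nitrogen.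

Compound 4, `O=S(=O)(NCCCNCc1cccc(Cl)c1)c1cc(C(F)(F)F)cc(C(F)(F)F)c1`, has not yet been measured. It differs from compound 1 in a single respect: 3-chlorophenyl in place of 4-chlorophenyl on a saturated chain carbon bound to an amine nitrogen. For the measured compounds named here, no measured step exchanges 4-chlorophenyl for 3-chlorophenyl; the only step at that site, from compound 1 to compound 3, changes the group itself and was itself modest. The data therefore give no ground for expecting a step beyond the scatter in this assay, and compound 4 is expected to come out close to compound 1. The expected step is a 1.1-fold higher number from compound 1 to compound 4 (0.05 log units; within the scatter). Compound 4 is estimated at 3000 nM, with a range from 1200 nM to 7500 nM.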

Compound 4, concentration for 50% growth inhibition: 8000 nM
Compound 4: middle estimate off by 2.7-fold (0.43 log units), on the low side, outside the stated range (above it).
By their numbers in this assay, from the lowest: compounds 2 and 1 (each within the scatter of the next); then compounds 3 and 4 (each within the scatter of the next).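

Moving the chlorine alone, with 3-chlorophenyl in place of 4-chlorophenyl on a saturated chain carbon bound to an amine nitrogen, gives a 3.0-fold higher number from compound 1 to compound 4 (0.47 log units; beyond the scatter) in this assay and so shows that this position responds to where the chlorine sits on the phenyl ring, not only to which group is present. The earlier change from compound 1 to compound 3 altered the group and its place together, whereas chloro in place of methoxy on an aromatic carbon gives a 1.3-fold higher number from compound 3 to compound 4 (0.10 log units; within the scatter) and thus separates compound 3 and compound 4 by no more than the scatter. Nothing available explains why the place of the chlorine matters here.

Whether a 4-methoxyphenyl group would stand with compound 1 or with compound 3 remains open, so the compounds shown cannot tell whether methoxy responds to its place as chloro does. Also open, going by these compounds, is whether a fluoro or a nitrile in place of the chloro, or a longer chain in the core of compound 1, would keep the same difference between 4-chlorophenyl and 3-chlorophenyl.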